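The source may hold more compounds than are shown below. What is called first, only, known or untested is meant among the compounds shown, and "the series" means these compounds.

In a functional assay on BT-549 cells (Homo sapiens) for inhibition, read by sulforhodamine B assay, with a stated time of 48 h, tested at 10 uM (on this read-out lower numbers stand for less inhibition and higher numbers for more inhibition at the one concentration tested (going by the name of the read-out)), compound 1 `COc1ccc(-c2cn3ccnc3c(-c3ccc4ncn(C5CCCCC5)c4c3)n2)cc1` gives 68.9%. Compound 2 `Fc1ccc(-c2cn3ccnc3c(-c3ccc4ncn(C5CCCCC5)c4c3)n2)cc1` gives 20.3%, and compound 3 `Fc1ccccc1-c1cn2ccnc2c(-c2ccc3ncn(C4CCCCC4)c3c2)n1` gives 4.08%, the lowest of the three: the step of a number 64.8 percentage points lower from compound 1 to compound 3 (beyond the scatter) and the step of a number 16.2 percentage points lower from compound 2 to compound 3 (beyond the scatter) both place compound 3 clearly below the others. Compound 4 `c1csc(-c2cn3ccnc3c(-c3ccc4ncn(C5CCCCC5)c4c3)n2)c1` differs from compound 3 in one place: thiophen-2-yl in place of 2-fluorophenyl on an aromatic carbon. Going by the values given here, no measured step exchanges the aromatic group for a thiophen-2-yl, so the only guide is that changing this group has moved inhibition strongly, as in a number 48.6 percentage points lower from compound 1 to compound 2 (beyond the scatter). Inhibition for compound 4 is therefore expected to move only modestly from compound 3, with the estimated step of a number 15.9 percentage points higher from compound 3 to compound 4 (beyond the scatter). Compound 4 is expected to give 20%, within 3% to 55%.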

Compound 4, a percentage reported as inhibition, at one concentration (the size of the read-out at that concentration, not a potency): 12.2%
The estimate for compound 4 lay 7.8 percentage points above the measured number, within the range that was stated.
By their numbers in this assay, from the lowest: compounds 3, 4 and 2 (each within the scatter of the next, the first and the last beyond it); then compound 1.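

Swapping the 2-fluorophenyl for thiophen-2-yl, a smaller five-membered ring containing sulfur, leaves inhibition within the usual scatter (a number 8.1 percentage points higher from compound 3 to compound 4 (within the scatter)), and the same holds against the 4-fluorophenyl (a number 8.1 percentage points lower from compound 2 to compound 4 (within the scatter)). At this position, a high number therefore does not simply return with any aromatic ring, since the 4-methoxyphenyl remains well apart (a number 56.7 percentage points lower from compound 1 to compound 4 (beyond the scatter)). No available evidence explains this difference. As far as these compounds go, it remains open whether the methoxy group itself matters, for example whether a methoxy on the thiophene ring or a 4-aminophenyl group would give a high number.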